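A few compounds are considered here, and "the series" means these few. Any claim that something is new, unique, unknown or untested is made for them only; others in the source may bear on it.

Measured so far:
Compound 1 `N#C/C(=C\c1c(F)c(F)c(F)c(F)c1F)C(=O)c1c[nH]c2ccccc12` gives 18000 nM in a functional assay on HT-29 cells (Homo sapiens) for inhibition, read by MTT assay, with a stated time of 72 h; a lower number here means a stronger inhibitor of growth, a higher number a weaker inhibitor of growth.
Compound 2 `COc1ccc(CNC(=O)/C(C#N)=C/c2ccc(Cl)o2)cc1` gives 9000 nM in this assay.

On these two numbers compound 2 cannot be separated from compound 1: the gap between them lies within the usual scatter of this assay. Compound 3 `COc1ccc(CNC(=O)/C(C#N)=C/c2ccc(Cl)cc2)cc1` carries 4-chlorophenyl in place of 5-chlorofuran-2-yl on a double-bonded chain carbon bound to a double-bonded chain carbon. For the measured compounds named here, no measured pair shows what such a change does, so no step beyond the scatter is expected in either direction. For compound 3 the estimate is 12000 nM, ranging from 4000 nM to 40000 nM, which means an expected step of a 1.3-fold higher number from compound 2 to compound 3 (0.12 log units; within the scatter).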

Compound 3, concentration for 50% growth inhibition: 7000 nM
Estimate against measurement, compound 3: 1.7-fold (0.23 log units) above, within the range that was stated.
By their numbers in this assay, from the lowest: compounds 3, 2 and 1 (each within the scatter of the next, the first and the last beyond it).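

For the compounds shown here, this is the first measured pair at this position. In this assay the swap to 4-chlorophenyl from 5-chlorofuran-2-yl gives a 1.3-fold lower number from compound 2 to compound 3 (0.11 log units; within the scatter) and so, in this pair, a five-membered aromatic ring with one hetero atom and a six-membered aromatic ring of carbon only cannot be told apart. No measurement bearing on the reason for this result is available.

Open, going by these compounds, is whether a group of another kind here, such as a phenyl ring carrying an amine or a carboxylic acid, would shift growth inhibition beyond the scatter. Also open, on these data alone, is what a methyl group in place of the chlorine would do.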